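This account rests on a few compounds, and the source may have more. Where it says the series, first, only, none or still open, it means among the compounds named here.

Compound 1 `COC(=O)C(c1ccccc1)n1nnnc1[C@@H](COCc1ccccc1)NC(=O)C(C)(C)N` gives 470 nM in an assay on isolated protein for displacement of a labelled ligand from growth hormone secretagogue receptor type 1 (Homo sapiens), with a stated time of 1 h; on this read-out lower numbers stand for stronger inhibition and higher numbers for weaker inhibition.
Compound 2 `CC(C)(N)C(=O)N[C@H](COCc1ccccc1)c1nnnn1CCC#N` gives 2940 nM in this assay.

Of these two numbers compound 2 stands highest, with a 6.3-fold higher number from compound 1 to compound 2 (0.80 log units; beyond the scatter) separating it from compound 1. Compound 3 `CC(C)(N)C(=O)N[C@H](COCc1ccccc1)c1nnnn1CCC(=O)NCc1ccccc1` differs from compound 2 by benzylcarbamoyl in place of cyano on a saturated chain carbon, two bonds along the chain from an aromatic nitrogen. Among the measured compounds shown here, the one measured step that bears on this, a 6.3-fold higher number from compound 1 to compound 2 (0.80 log units; beyond the scatter), ran toward a higher number when the ring-bearing group on the aromatic nitrogen gave way to the shorter chain; restoring a ring there is therefore expected to lower the number, though the entering group is not the one that left. For compound 3 the estimate in this assay is 900 nM (range 250 nM to 3500 nM). That amounts to an expected 3.3-fold lower number from compound 2 to compound 3 (0.51 log units; beyond the scatter).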

Compound 3, inhibition constant: 1070 nM
Beside the measured number, compound 3's estimate is 1.2-fold (0.08 log units) below it; the range from low to high includes it.
By their numbers in this assay, from the lowest: compound 1; then compound 3; then compound 2.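

In this assay, the position on the chain in compound 2 takes a far larger group, and the change gives a 2.7-fold lower number from compound 2 to compound 3 (0.44 log units; beyond the scatter) as benzylcarbamoyl, with its 10 heavy atoms, replaces cyano. A six-membered aromatic ring carried on this chain thus goes with a lower number, though the carbonyl and the amide hydrogen enter along with it. Nothing available explains this step. The compounds shown leave open whether the ring or the amide accounts for the step, which a phenyl or a plain carboxamide on this saturated chain carbon would separate, and how a longer chain would read.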